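Working notes: three measured sulfonamides and one untested analogue

The compounds below may be only part of what the source reports. "The series", "measured", "known", "first", "only" and "open" are said of these compounds alone.

Measured so far in a functional assay on HepG2 cells (Homo sapiens) for inhibition, read by sulforhodamine B assay, with a stated time of 24 h; on this read-out lower numbers stand for stronger inhibition and higher numbers for weaker inhibition:
compound 1, `Nc1ncnc2c1c(-c1ccccc1)cn2-c1ccc(S(=O)(=O)Nc2nccs2)cc1`, gives 4240 nM
compound 2, `N#Cc1c(-c2ccccc2)cn(-c2ccc(S(=O)(=O)Nc3nccs3)cc2)c1NC(N)=O`, gives 4020 nM
compound 3, `N#Cc1c(-c2ccccc2)cn(-c2ccc(S(=O)(=O)Nc3ccccn3)cc2)c1NC(N)=O`, gives 4120 nM

Compound 3 carries the second highest of the three numbers, but the set is flat: its gap to compound 2 and its gap to compound 1 both sit within the scatter, so no order among the three can be read from these values. Among the measured compounds shown here, the single step between neighbours that differ in one place, a 1.0-fold higher number from compound 2 to compound 3 (0.01 log units; within the scatter), concerns the group on the sulfonamide nitrogen and lies within the scatter.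

Compound 4, `N#Cc1c(-c2ccccc2)cn(-c2ccc(S(=O)(=O)Nc3ccccn3)cc2)c1NC(=O)CCC(=O)O`, is the next candidate. Relative to compound 3 the change is 2-carboxyethyl in place of amino on a carbonyl carbon; one bond further out it reads carbamoyl to (2-carboxyethyl)carbonyl, or ureido to ((2-carboxyethyl)carbonyl)amino. For the measured compounds named here, no measured step touches this carbonyl carbon, and the one step that exists sits elsewhere on the molecule, so nothing among the measured compounds points to a direction. The default expectation is therefore a step of no size beyond the scatter, anchored on compound 3, with a wide range to cover the absence of any precedent for this change.

Compound 4 is estimated at 5000 nM in this assay, within 1500 nM to 20000 nM. This estimate corresponds to an expected step of a 1.2-fold higher number from compound 3 to compound 4 (0.08 log units; within the scatter).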

Compound 4, half-maximal inhibitory concentration: 3750 nM
Compound 4: middle estimate off by 1.3-fold (0.12 log units), on the high side, and the stated range covers the measured number.
By their numbers in this assay, from the lowest: compounds 4, 2, 3 and 1 (each within the scatter of the next).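

In this assay, among the compounds shown here, this is the first reading of a change on the carbonyl carbon whose other neighbour is the amide-type nitrogen, and it gives a 1.1-fold lower number from compound 3 to compound 4 (0.04 log units; within the scatter). For the compounds shown here, exchanging amino, a single nitrogen, for 2-carboxyethyl, with its 5 heavy atoms, therefore leaves the read-out within the scatter, so this position shows the same flat picture that the earlier compounds showed only for the group on the sulfonamide nitrogen, and compound 4 at 3750 nM joins a set in which each compound lies within the scatter of the next. No supporting data bear on why this larger group leaves the number within the scatter.

As far as these compounds go, it remains open whether a longer chain ending in a carboxylic acid, a methyl ester of the 2-carboxyethyl group or a chain ending in a primary amine on this carbonyl carbon would give a step beyond the scatter. From the compounds shown here alone, it is also open whether 2-carboxyethyl would give the same reading when paired with the 1,3-thiazol-2-yl group on the sulfonamide nitrogen of compound 2.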